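A few compounds are considered here, and "the series" means these few. Any claim that something is new, unique, unknown or untested is made for them only; others in the source may bear on it.

Measured compounds in a functional assay on HCT-116 cells (Homo sapiens) for inhibition, read by MTT assay, with a stated time of 72 h; a higher number here means a weaker inhibitor of growth, a lower number a stronger inhibitor of growth:
compound 1 `O[C@H](COCCOC[C@@H](O)Cc1cn(Cc2ccc3ccccc3c2)nn1)Cc1ccc(-c2ccccc2)cc1` gives 8600 nM
compound 2 `COC1=C(C)C(=O)C(CCCCCCCCCCn2cc(C[C@H](O)COCCOC[C@@H](O)Cc3ccc(-c4ccccc4)cc3)nn2)=C(C)C1=O` gives 4000 nM
compound 3 `O=C1COc2ccc(-n3cc(C[C@H](O)COCCOC[C@@H](O)Cc4ccc(-c5ccccc5)cc4)nn3)cc2N1` gives 42500 nM

Compound 3 stands at the highest number of the three in this assay. Going by the values given here, its nearest neighbour is compound 1, and the single measured step at the aromatic nitrogen is a 4.9-fold higher number from compound 1 to compound 3 (0.69 log units; beyond the scatter). Among the compounds with values here, compound 2, which also carries a different group on that nitrogen, gives a number lower than that of compound 3, but no single-point step connects the two.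

Compound 4 `O[C@H](COCCOC[C@@H](O)Cc1cn(-c2cccs2)nn1)Cc1ccc(-c2ccccc2)cc1` is reached from compound 3 by a group of 5 heavy atoms (4 carbon, 1 sulfur; one five-membered aromatic ring with 1 hetero atom) in place of a group of 11 heavy atoms (8 carbon, 1 nitrogen, 2 oxygen; one six-membered non-aromatic ring with 2 hetero atoms, one six-membered aromatic ring of carbon only), on an aromatic nitrogen. Within the data shown here, the only measured step that bears on this position is the one from compound 1 to compound 3, where the group now leaving compound 3 had raised the number by a modest but real amount. Among the measured compounds shown here, no measured step shows a five-membered aromatic ring on this nitrogen, so the size of the move is uncertain. Because the entering group of compound 3 produced a 4.9-fold higher number from compound 1 to compound 3 (0.69 log units; beyond the scatter), its removal in compound 4 is expected to lower the number, by roughly a 2.8-fold lower number from compound 3 to compound 4 (0.45 log units; beyond the scatter). Compound 4 is therefore estimated at 15000 nM in this assay, with a range from 5000 nM to 45000 nM.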

Compound 4, concentration for 50% growth inhibition: 33400 nM
For compound 4 the middle estimate is 2.2-fold (0.35 log units) below the measured one, within the range that was stated.
By their numbers in this assay, from the lowest: compound 2; then compound 1; then compounds 4 and 3 (each within the scatter of the next).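

In this assay, the step of a 1.3-fold lower number from compound 3 to compound 4 (0.10 log units; within the scatter) shows that the group of 11 heavy atoms, with its hydrogen-bond donor, and the thiophen-2-yl group of 5 heavy atoms cannot be told apart at this aromatic nitrogen, so among these two compounds the heavy-atom count of the group gives no separation. The step of a 3.9-fold higher number from compound 1 to compound 4 (0.59 log units; beyond the scatter) shows that the (naphthalen-2-yl)methyl group of compound 1 is set apart from thiophen-2-yl as well as from the group in compound 3, which places compound 1 on the lower side of both with two separate measured steps. No measurement at hand explains these results, whether for the group of compound 1 or for the closeness of compound 3 and compound 4.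

The step from compound 1 to compound 4 changes the ring and removes the methyl link at once, so a thiophen-2-ylmethyl group on the same nitrogen would be needed to separate the two changes. Going by these compounds, it also stays open whether an amine or a carboxylic acid on the group at this nitrogen would shift the number at all.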